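Swapping bromo for hydroxy on the pendant ring

A few compounds are considered here, and "the series" means these few. Any claim that something is new, unique, unknown or untested is made for them only; others in the source may bear on it.

Three compounds sharing one core have been measured in a functional assay on RAW264.7 cells (Mus musculus) for inhibition; a higher number here means a weaker inhibitor, a lower number a stronger inhibitor:
compound 1 `O=C1/C(=C/c2ccccc2)CCc2ccc(O)cc21` gives 710 nM;
compound 2 `O=C1/C(=C/c2cccc(F)c2)CCc2ccc(O)cc21` gives 830 nM;
compound 3 `O=C1/C(=C/c2cccc(Br)c2)CCc2ccc(O)cc21` gives 480 nM.

Compound 3 sits at the low end of these three numbers, yet the steps of a 1.5-fold lower number from compound 1 to compound 3 (0.17 log units; within the scatter) and a 1.7-fold lower number from compound 2 to compound 3 (0.24 log units; within the scatter) both lie within the scatter, so the three cannot truly be ranked. Compound 4 `O=C1/C(=C/c2cccc(O)c2)CCc2ccc(O)cc21` follows from compound 3 by hydroxy in place of bromo on an aromatic carbon. Among the measured compounds shown here, the steps that bear on this spot, a 1.2-fold higher number from compound 1 to compound 2 (0.07 log units; within the scatter) and a 1.5-fold lower number from compound 1 to compound 3 (0.17 log units; within the scatter), show that exchanging the group there has so far shifted the number only within the scatter, although none of them brings in a hydroxy. A step of about a 1.5-fold higher number from compound 3 to compound 4 (0.16 log units; within the scatter) is therefore expected, with no clear direction. Compound 4 is estimated at 700 nM, ranging from 300 nM to 1600 nM.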

Compound 4, half-maximal inhibitory concentration: 810 nM
Beside the measured number, compound 4's estimate is 1.2-fold (0.06 log units) below it, within the range that was stated.
By their numbers in this assay, from the lowest: compounds 3, 1, 4 and 2 (each within the scatter of the next).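

In this assay, replacing bromo, which has no hydrogen-bond donor, with hydroxy, which has one, gives a 1.7-fold higher number from compound 3 to compound 4 (0.23 log units; within the scatter). Hydroxy also stays level with the other two groups, with a 1.0-fold lower number from compound 2 to compound 4 (0.01 log units; within the scatter) and a 1.1-fold higher number from compound 1 to compound 4 (0.06 log units; within the scatter). Across the compounds shown, hydrogen, fluoro, bromo and hydroxy at this position therefore cannot be told apart in this measurement, and no supporting data offer an explanation.

On these data alone, whether an amine or a carboxylic acid here would move the number beyond the scatter remains open. The same question stands for a longer chain such as propoxy.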